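The compounds below may be only part of what the source reports. "The series", "measured", "known", "first", "only" and "open" are said of these compounds alone.

In a functional assay on HL-60 cells (Homo sapiens) for antiproliferative activity, read by XTT assay, with a stated time of 72 h (a lower number here means a stronger inhibitor, a higher number a weaker inhibitor), compound 1 `CNc1ncnc2c1c(-c1ccoc1)cn2[C@@H]1O[C@H](CO)[C@@H](O)[C@H]1O`, bearing furan-3-yl, gives > 15000 nM, which is a limit of the assay and not a number. Compound 2 `CNc1ncnc2c1c(-c1cccs1)cn2[C@@H]1O[C@H](CO)[C@@H](O)[C@H]1O`, bearing thiophen-2-yl, gives > 20000 nM, also a limit. For the measured compounds named here, compound 3 `CNc1ncnc2c1c(-c1cc3ccccc3o1)cn2[C@@H]1O[C@H](CO)[C@@H](O)[C@H]1O`, bearing 1-benzofuran-2-yl, gives 8950 nM, the only true number among the three. Compound 4 `CNc1ncnc2c1c(I)cn2[C@@H]1O[C@H](CO)[C@@H](O)[C@H]1O` has iodo in place of 1-benzofuran-2-yl on an aromatic carbon. Two measured steps introduced that same 1-benzofuran-2-yl group: an at least 1.6-fold lower number from compound 1 to compound 3 (0.22 log units; that floor lies within the scatter) and an at least 2.2-fold lower number from compound 2 to compound 3 (0.34 log units; beyond the scatter). Going by these compounds, both are small, so removing the group is expected to cost little, although iodo itself is untested and this assay may again report only a limit. The expected change is a 1.3-fold higher number from compound 3 to compound 4 (0.13 log units; within the scatter), toward a slightly higher number at most. For compound 4 the estimated value is 12000 nM, with an expected range of 3000 nM to 40000 nM.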

Compound 4, half-maximal inhibitory concentration: > 20000 nM
Compound 4 was reported as a limit; the forecaster's own chance of this, stated with the estimate: 50%; at least 1.6-fold (0.22 log units) between middle value and limit.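

In this assay, replacing the two-ring 1-benzofuran-2-yl group with a single iodine atom gives an at least 2.2-fold higher number from compound 3 to compound 4 (0.34 log units; beyond the scatter), so a change at this position, on the five-membered aromatic ring, can produce a step beyond the usual scatter. Iodo now joins furan-3-yl and thiophen-2-yl in giving only a limit, and 1-benzofuran-2-yl alone gives a true number. The steps from compound 1 and compound 2 to compound 4 cannot be read: the limit of > 20000 nM in this assay, at which 2 of the 4 values shown sit.

Going by these compounds, whether an amine or a naphthalen-2-yl group here would give a true number remains open.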